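The source may report more compounds than this note shows. Statements on the series, on what has been measured and on what is new or still open speak of the compounds shown alone.

Measured in an ADME assay on microsomes from liver (Rattus norvegicus, strain Sprague-Dawley) for metabolic stability, read by LC-MS, using NADPH, with a stated time of 45 min, tested at 3 uM; a lower number here means that the compound disappears faster, a higher number that the compound lasts longer:
- compound 1 `C1CCC(C(CC2CCCCN2)C2CC2)CC1`: 0.05 h
- compound 2 `Fc1ccc(C(CC2CCCCN2)C2CCCCC2)cc1`: 0.117 h

Compound 2 stands higher of the two. Among the compounds with values here, the series so far offers a single measured step, a 2.3-fold higher number from compound 1 to compound 2 (0.37 log units; beyond the scatter), which exchanges cyclopropyl for 4-fluorophenyl and lies beyond the scatter, though it is modest.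

Next is compound 3 `C1CCC(C(CC2CCCCN2)C2CCOCC2)CC1`, with the change oxan-4-yl in place of 4-fluorophenyl on a saturated chain carbon bound to a saturated chain carbon and a saturated ring carbon. Within the data shown here, no measured compound carries oxan-4-yl, so only that one modest step at this place bears on the question, and it gives weak guidance. No change beyond the scatter is expected, with a slight lean upward: the estimated move is a 1.3-fold higher number from compound 2 to compound 3 (0.11 log units; within the scatter). For compound 3 the expected half-life is 0.15 h, with an estimated range of 0.06 h to 0.4 h.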

Compound 3, half-life: 0.517 h
Beside the measured number, compound 3's estimate is 3.4-fold (0.54 log units) below it, and the stated range ends below it.
By their numbers in this assay, from the lowest: compound 1; then compound 2; then compound 3.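

At this place, on a saturated chain carbon bound to a saturated chain carbon and a saturated ring carbon, oxan-4-yl gives the longest half-life of the three groups in this assay (a 4.4-fold higher number from compound 2 to compound 3 (0.65 log units; beyond the scatter); a 10-fold higher number from compound 1 to compound 3 (1.01 log units; beyond the scatter)). The earlier step from cyclopropyl to 4-fluorophenyl (a 2.3-fold higher number from compound 1 to compound 2 (0.37 log units; beyond the scatter)) showed only a modest gain, whereas these results show that this place can carry a much larger one, reached with a non-aromatic ring with 1 hetero atom. No supporting data bear on what lies behind this rise.

Within the data shown here, with only one ring bearing a hetero atom in the set, it remains open whether the ring oxygen itself matters. A piperidin-4-yl ring, a plain phenyl or a carboxylic acid at this place would help to settle that.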